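Peroxide series: ring-carbon epimer of compound 2

A few compounds are considered here, and "the series" means these few. Any claim that something is new, unique, unknown or untested is made for them only; others in the source may bear on it.

Measured compounds:
- compound 1 `C=C1CCCC(C)(C)C1CC[C@]1(C)CC[C@H]([C@@H](C)C(=O)OC)OO1`: 4540 nM
- compound 2 `C=C1CCC[C@H]2[C@](C)(CC[C@]3(C)CC[C@@H]([C@@H](C)C(=O)O)OO3)[C@@H](C)CC[C@]12C`: 970 nM
- compound 3 `C=C1CCCC(C)(C)C1(O)CC/C(C)=C/CC[C@]1(C)CC[C@@H]([C@@H](C)C(=O)OC)OO1`: > 17500 nM

In a functional assay on COLO 205 cells (Homo sapiens) for inhibition (on this read-out lower numbers stand for stronger inhibition of growth and higher numbers for weaker inhibition of growth), compound 2 gives 970 nM, the lowest of the two numbers shown. Compound 1 gives 4540 nM in this assay, a higher number by a margin beyond the usual scatter. For compound 3 this assay reports only a limit, > 17500 nM, so no number is known for it (the limit of > 17500 nM in this assay, at which 1 of the 3 values shown sits).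

The next compound, compound 4 `C=C1CCC[C@H]2[C@](C)(CC[C@]3(C)CC[C@H]([C@@H](C)C(=O)O)OO3)[C@@H](C)CC[C@]12C`, keeps the core and the free acid of compound 2. (the two compounds have the same atoms and bonds and differ only in configuration as drawn: 1 of 7 stereo elements differ; a stereocentre at a saturated ring carbon is drawn S in compound 2 and R in compound 4). Within the data shown here, no step between two measured compounds of this kind is available here, so the size and direction of the change are open; the expectation rests on compound 2 alone, at 970 nM, with a wide range to either side.

Compound 4 is expected to give about 1500 nM in this assay, with a plausible range from 400 nM to 6000 nM. The expected step is a 1.5-fold higher number from compound 2 to compound 4 (0.19 log units; within the scatter).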

Compound 4, concentration for 50% growth inhibition: 2180 nM
The estimate for compound 4 lay 1.5-fold (0.16 log units) below the measured number, and the stated range covers the measured number.
By their numbers in this assay, from the lowest: compound 2; then compound 4; then compound 1. At a limit, above all of these: compound 3.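

In this assay, inverting the saturated ring carbon alone gives a 2.2-fold higher number from compound 2 to compound 4 (0.35 log units; beyond the scatter), so with the core and the free acid held fixed, this stereocentre has a modest but readable effect on growth inhibition. The earlier compounds shown here differ from one another in more than one place and offered no such single-change reading. The step can be assigned to this one centre because nothing else changes: the fact that compounds 2 and 4 differ only in the configuration as drawn.

On these data alone, what the other stereo elements contribute remains open, as does whether a primary amide in place of the free acid would keep the order seen for compound 2 and compound 4. Compound 3 offers no number for comparison, since its value is a limit, > 17500 nM.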